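The compounds below may be only part of what the source reports. "The series", "measured", "known", "first", "only" and "open" are said of these compounds alone.

Measured compounds:

compound 1 `Cn1c(=O)n2c3c1c(=O)nc(N)n3CC1OC2[C@H](O)[C@@H]1O`: 0%
compound 2 `COc1ccc(Cn2c(=O)n(C3OC(CO)[C@@H](O)[C@H]3O)c3nc(N)nc(O)c32)cc1`: 14%
compound 3 `Cn1c(=O)n([C@@H]2O[C@H](CO)[C@H]3OC(C)(C)O[C@H]32)c2nc(N)nc(O)c21`: 17%

All three numbers come from a functional assay on the whole organism with Mus musculus as the target; on this read-out lower numbers stand for smaller maximal responses and higher numbers for larger maximal responses. Compound 2 stands second highest of the three. Its nearest neighbour is compound 3, whose number lies three points higher, a gap within the usual scatter, so the two cannot be told apart. The furthest is compound 1, whose number lies lower by a gap beyond the scatter; compound 1 gives no response at all in this assay.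

Compound 4 `Cn1c(=O)n(C2OC(CO)[C@@H](O)[C@H]2O)c2nc(N)nc(O)c21` has not been measured. It is reached from compound 2 by one change: hydrogen in place of 4-methoxyphenyl on a saturated chain carbon bound to an aromatic nitrogen

For the measured compounds named here, no pair of measured compounds differs in this single place, so the series itself gives no measured step for such a change. What is known is that all three measured compounds sit low, and that the largest spread among them is modest. The step from compound 2 to compound 4 is therefore expected to be small: most likely a drop of a few points, possibly none beyond the scatter, with a rise beyond the scatter looking least likely given the low level of the whole set. For compound 4 the expected maximal response is 8%, with a range from 0% to 20%, an expected step of a number 6 percentage points lower from compound 2 to compound 4 (within the scatter).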

Compound 4, largest response reached (reported as maximal response), in percent of the reference or control that the assay uses: 100%
Estimate against measurement, compound 4: 92 percentage points below; the measured number lies above the stated range.
By their numbers in this assay, from the lowest: compound 1; then compounds 2 and 3 (each within the scatter of the next); then compound 4.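

Replacing 4-methoxyphenyl with hydrogen on a saturated chain carbon bound to an aromatic nitrogen, which amounts to 4-methoxybenzyl to methyl, gives a number 86 percentage points higher from compound 2 to compound 4 (beyond the scatter) in this assay. For the compounds shown here, this place is therefore far from neutral for the read-out: a single change here is enough to separate a low maximal response from a high one, a sensitivity that the earlier compounds, with no measured step among them, could not reveal. Nothing available accounts for the size of this step, and the data give no reason for it.

From the compounds shown here alone, with only 4-methoxybenzyl and methyl compared at this place, it remains open whether an ethyl group, an unsubstituted benzyl group or a longer chain would stay near the number of compound 4 or fall towards that of compound 2. Also open, going by these compounds, is how an amine or a carboxylic acid carried on that chain would read out, and whether a change at this place has a similar effect on any other part of the series.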